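The source may hold more compounds than are shown below. What is called first, only, known or untested is meant among the compounds shown, and "the series" means these compounds.

Notes on the series in a functional assay on the whole organism (Tail, strain ICR) with Mus musculus as the target, in the tail flick test, with a stated time of 150 min, at a dose of 25 umol/kg by the oral route; a higher number here means a stronger effect of the compound at the dose given, a lower number a weaker effect. Compound 1 `O=C(CN(c1nc(Cl)nc2[nH]cnc12)C1CC1)N[C@@H](CO)C(=O)OCc1ccccc1` gives 27.9% in this assay, the highest of the three numbers recorded. Compound 2 `NC(=O)CC[C@H](NC(=O)CN(c1ncnc2c1ncn2C1CCCCO1)C1CC1)C(=O)OCc1ccccc1` gives 10.7% in this assay, a number lower than that of compound 1 by more than the usual scatter. Compound 3 `O=C(O)[C@@H]1CCCN1C(=O)CN(c1nc(Cl)nc2[nH]cnc12)C1CC1` gives 7.29% in this assay, also lower than compound 1 beyond the scatter. The three measured compounds differ from one another in more than one place, so no single-point step can be read from them.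

Compound 4 `CC[C@H](C)[C@H](NC(=O)CN(c1nc(Cl)nc2[nH]cnc12)C1CC1)C(=O)OCc1ccccc1` differs from compound 1 in one place: sec-butyl in place of hydroxymethyl on a saturated chain carbon bound to an amide-type nitrogen and a carbonyl carbon. Among the measured compounds shown here, no step between two measured compounds that differ in a single place is available in this assay, so the size of the step to compound 4 cannot be calibrated from the measured numbers. A step of modest size is expected in this assay, in either direction, and it may well stay within the scatter. For compound 4 a read-out of 25% is expected in this assay, within a range of 8% to 45%. The step of a number 2.9 percentage points lower from compound 1 to compound 4 (within the scatter) is thus the expected change.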

Compound 4, a percentage reported as activity, at one dose (the size of the read-out at that dose, not a potency): 6.9%
Compound 4: the middle estimate sits 18.1 percentage points above what was measured; the measured number lies below the stated range.
By their numbers in this assay, from the lowest: compounds 4, 3 and 2 (each within the scatter of the next); then compound 1.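

In this assay, among the compounds shown here, the change gives the first single-place step: a number 21 percentage points lower from compound 1 to compound 4 (beyond the scatter), with sec-butyl in place of hydroxymethyl on a saturated chain carbon bound to an amide-type nitrogen and a carbonyl carbon. The read-out at this dose therefore depends on the group at this position, and the hydroxymethyl, which carries a hydrogen-bond donor and acceptor, goes with the higher number here. Nothing available explains the drop.

The compounds shown leave open whether the step follows the loss of the hydroxyl or the arrival of the sec-butyl, which a methyl group, a longer hydroxyalkyl chain or a carboxylic acid at the same place could help separate. Going by these compounds, with one step at one dose and one time, it also remains open whether this holds for other changes at this position.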